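Chloro for Methyl on Two Unrelated Cores

This account rests on a few compounds, and the source may have more. Where it says the series, first, only, none or still open, it means among the compounds named here.

Measured so far:
Compound 1 `Cc1ccc(NC(=O)COc2nc3ccccc3nc2/C=C\c2ccncc2)cc1` in a functional assay on K562 cells (Homo sapiens) for inhibition, read by MTT assay, with a stated time of 24 h (on this read-out higher numbers stand for weaker inhibition and lower numbers for stronger inhibition), gives > 100000 nM, a limit of this assay.
Compound 2 `O=C(COc1nc2ccccc2nc1/C=C\c1ccncc1)Nc1ccc(Cl)cc1` in this assay gives 49900 nM.
Compound 3 `Cc1ccc(C(=O)Nc2ccc(Cn3c(=O)c(C)nc4ccccc43)cc2)cc1` in this assay gives > 100000 nM, a limit of this assay.

The core of compound 1 and the core of compound 3 are not the same, and the difference between the two cores is not broken down here. Compound 1 and compound 2 differ in one place: chloro in place of methyl on an aromatic carbon. That change gave an at least 2.0-fold lower number from compound 1 to compound 2 (0.30 log units; that floor lies within the scatter); since compound 1 sits at the limit of > 100000 nM in this assay, at which 2 of the 3 values shown sit, only this floor is known for the step.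

Compound 4 `Cc1nc2ccccc2n(Cc2ccc(NC(=O)c3ccc(Cl)cc3)cc2)c1=O` stands to compound 3 as compound 2 stands to compound 1, and the change is the same one: chloro in place of methyl on an aromatic carbon, in the same place on the ring. For compound 4 a step of about an at least 1.4-fold lower number from compound 3 to compound 4 (0.15 log units; that floor lies within the scatter) is expected, resting on the step of an at least 2.0-fold lower number from compound 1 to compound 2 (0.30 log units; that floor lies within the scatter) seen on the other core. Compound 4 is therefore estimated at 70000 nM, within 30000 nM to 200000 nM, with a fair chance that this assay again reports only a limit.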

Compound 4, half-maximal inhibitory concentration: > 100000 nM
Compound 4 was reported as a limit; the forecaster's own chance of this, stated with the estimate: 55%; middle value at least 1.4-fold (0.15 log units) away from the limit.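

In this assay compound 4 gives > 100000 nM, which is a limit. Compound 3 gives > 100000 nM, also a limit. No step can be read between compound 3 and compound 4, as both stand at the same value: the limit of > 100000 nM in this assay, at which 3 of the 4 values shown sit. The compounds shown leave open whether chloro in place of methyl changes the number at all on the core of compound 3.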